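A hydroxymethyl swap on compound 1

The source may report more compounds than this note shows. Statements on the series, on what has been measured and on what is new or still open speak of the compounds shown alone.

Going by the values given here, in an ADME assay on Vero cells (Chlorocebus sabaeus) for cytotoxicity, read by MTT assay (on this read-out lower numbers stand for higher toxicity in this test and higher numbers for lower toxicity in this test), compound 1 `Cn1nc(C(F)(F)F)cc1C(=O)Nc1ccc(S(=O)(=O)N2CCC(C(F)(F)F)CC2)cc1` gives 159000 nM, the only true number so far. Compound 2 `Cn1nc(C(F)(F)F)cc1C(=O)Nc1ccc(S(=O)(=O)N2CCC(NC(=O)OC(C)(C)C)CC2)cc1` reaches only a limit of the assay, > 300000 nM. Compound 3 `Cn1nc(C(F)(F)F)cc1C(=O)Nc1ccc(S(=O)(=O)N2CCCCC2CO)cc1` differs from compound 1 on the sulfonyl sulfur: 2-(hydroxymethyl)piperidin-1-yl in place of 4-(trifluoromethyl)piperidin-1-yl on a sulfonyl sulfur. Just one measured step bears on this, and only loosely: an at least 1.8-fold higher number from compound 1 to compound 2 (0.27 log units; that floor lies within the scatter), with (tert-butoxycarbonyl)amino in place of trifluoromethyl on a saturated ring carbon. On that thin evidence, the expected step is a 1.3-fold higher number from compound 1 to compound 3 (0.10 log units; within the scatter), and no change beyond the scatter is expected in this assay. Compound 3 is estimated at 200000 nM, within an expected range of 100000 nM to 300000 nM.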

Compound 3, half-maximal cytotoxic concentration: 159000 nM
Compound 3: middle estimate off by 1.3-fold (0.10 log units), on the high side; measured number inside the range.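

Replacing 4-(trifluoromethyl)piperidin-1-yl with 2-(hydroxymethyl)piperidin-1-yl on a sulfonyl sulfur gives no change at the digits printed from compound 1 to compound 3 (within the scatter) in this assay. The entering group has a hydrogen-bond donor and a hydrogen-bond acceptor, the leaving group has neither, and the read-out does not separate them. Going by these compounds alone, this is the first comparison at this position between two true numbers.

Going by these compounds, whether a carboxylic acid or a free amine in place of the hydroxymethyl would move the number remains open. How high the number can go at this position cannot be read from compound 2, because its value is only a limit: the limit of > 300000 nM in this assay, at which 1 of the 3 values shown sits.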